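From Cyclopentyl to Cyclobutyl: An Expected Lipophilicity Shift

A few compounds are considered here, and "the series" means these few. Any claim that something is new, unique, unknown or untested is made for them only; others in the source may bear on it.

Compound 2 `O=C(O)CCNC(=O)c1ccc(C(Oc2ccc(-n3cc(C(F)(F)F)cn3)cc2)C2CCCC2)cc1` stands highest of the two measured compounds in a physicochemical assay for lipophilicity, using the shake flask method, at pH 7.4 (on this read-out higher numbers stand for higher lipophilicity and lower numbers for lower lipophilicity), where compound 2 gives 3.3. Compound 1 `CCCC(Oc1ccc(-n2cc(Cl)cn2)cc1)c1ccc(C(=O)NCCC(=O)O)cc1` gives 2.6 in this assay, a number below that of compound 2 by more than the scatter. Compound 3 `O=C(O)CCNC(=O)c1ccc(C(Oc2ccc(-n3cc(C(F)(F)F)cn3)cc2)C2CCC2)cc1` has not yet been measured. It differs from compound 2 in one place: cyclobutyl in place of cyclopentyl on a saturated chain carbon bound to an aromatic carbon and an oxygen on an aromatic ring. The step of a number 0.40 log units lower from compound 2 to compound 3 (beyond the scatter) is expected to be small and downward, close to the edge of the scatter, with cyclobutyl entering in place of cyclopentyl. Compound 3 is therefore estimated at 2.9, within 2.5 to 3.3.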

Compound 3, distribution coefficient: 2.6
For compound 3 the middle estimate is 0.30 log units above the measured one; measured number inside the range.
By their numbers in this assay, from the lowest: compounds 1 and 3 (each within the scatter of the next); then compound 2.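

Cyclobutyl in place of cyclopentyl, on a saturated chain carbon bound to an aromatic carbon and an oxygen on an aromatic ring, changes the reading in this assay beyond the scatter: a number 0.70 log units lower from compound 2 to compound 3 (beyond the scatter). Among these compounds, this is the first evidence that ring size at this position registers on this read-out, since compound 1 differs from compound 2 in more than one place. Nothing available explains the size of this step. As far as these compounds go, how a cyclohexyl or an isopropyl group would read at this position remains open. So does whether the step would persist with chloro in place of trifluoromethyl.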